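Cytotoxicity of aryl hydrazides on canine kidney cells

The source may hold more compounds than are shown below. What is called first, only, known or untested is meant among the compounds shown, and "the series" means these compounds.

Three hydrazide analogues have been measured in a toxicity assay on MDCK cells (Canis lupus familiaris) for cytotoxicity, read by CCK-8 assay, with a stated time of 48 h; on this read-out higher numbers stand for lower toxicity in this test and lower numbers for higher toxicity in this test. Compound 1 `CC(C)(C)c1ccc(C(=O)NNc2c(Br)cccc2Br)cc1` gives > 100000 nM, which is a limit of the assay and not a number. Compound 2 `COc1ccccc1C(=O)NNc1c(Br)cccc1Br` gives > 100000 nM, again a limit rather than a measured number. Compound 3 `CCOc1ccc(C(=O)NNc2c(C)cccc2C)cc1` gives > 100000 nM, likewise a limit. Thus compound 1 stands where the whole measured set stands: all three values sit at the limit of > 100000 nM in this assay, at which 3 of the 3 values shown sit, and no compound has shown a measurable half-maximal cytotoxic concentration in this assay.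

Compound 4 `O=C(NNc1c(Br)cccc1Br)c1ccc(O)cc1` is the next member to be tested in this assay. It differs from compound 1 in one place: hydroxy in place of tert-butyl on an aromatic carbon. Going by the values given here, no step between two measured compounds is available, so there is nothing that links a change of substituent to a change in cytotoxicity; the only fact to build on is that each measured compound sits at the limit.

The expectation for compound 4 is therefore a step from compound 1 of a number no higher from compound 1 to compound 4 (the limit leaves the size open), that is, none beyond the usual scatter. Compound 4 is estimated at 100000 nM in this assay, with a range from 50000 nM to 300000 nM, and most likely the assay will again report only a limit.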

Compound 4, half-maximal cytotoxic concentration: > 100000 nM
Compound 4: only a limit was reported; the forecaster's own chance of this, stated with the estimate: 80%; the middle value lies on the limit itself.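

Compound 4 gives > 100000 nM in this assay, a limit and not a number, so the step from compound 1 to compound 4, hydroxy in place of tert-butyl, cannot be read. The series stands at a single limit: the limit of > 100000 nM in this assay, at which 4 of the 4 values shown sit. The compounds shown leave open at what concentration, if any, a member of this series becomes cytotoxic.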